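Phenoxy in place of sulfamoyl: the aryl ether step

The source may hold more compounds than are shown below. What is called first, only, known or untested is meant among the compounds shown, and "the series" means these compounds.

Compound 1 `O=C1C(Nc2ccc(CO)cc2)=CC(=O)c2ncncc21` gives 1000 nM in a functional assay on PANC-1 cells (Homo sapiens) for cytotoxicity, read by MTT assay, with a stated time of 72 h (on this read-out lower numbers stand for stronger inhibition and higher numbers for weaker inhibition), and compound 2 `COc1ccc(NC2=CC(=O)c3ncncc3C2=O)cc1` gives 800 nM in the same assay. Compound 3 `NS(=O)(=O)c1ccc(NC2=CC(=O)c3ncncc3C2=O)cc1` reaches only the limit of the assay, > 10000 nM, so no number is known for it. Thus compound 3 sits at the weak end of the three values shown. The change an at least 10-fold higher number from compound 1 to compound 3 (1.00 log units; beyond the scatter) and the change an at least 12-fold higher number from compound 2 to compound 3 (1.09 log units; beyond the scatter) both point the same way, while a 1.3-fold lower number from compound 1 to compound 2 (0.10 log units; within the scatter) stays within the scatter.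

Compound 4 `O=C1C(Nc2ccc(Oc3ccccc3)cc2)=CC(=O)c2ncncc21` is not yet measured. The change from compound 3 to compound 4 is phenoxy in place of sulfamoyl on an aromatic carbon; the phenoxy group carries an ether oxygen like the methoxy of compound 2 and no hydrogen-bond donor. Both measured steps toward sulfamoyl worsened the number, so removing sulfamoyl is expected to move the number back in the other direction, by an at least 6.6-fold lower number from compound 3 to compound 4 (0.82 log units; beyond the scatter), the uncertainty being wide since compound 3 is a limit. Compound 4 is therefore expected to give about 1500 nM in this assay, within 400 nM to 6000 nM.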

Compound 4, half-maximal inhibitory concentration: 1800 nM
The estimate for compound 4 lay 1.2-fold (0.08 log units) below the measured number; the measured number falls inside the stated range.
By their numbers in this assay, from the lowest: compounds 2, 1 and 4 (each within the scatter of the next, the first and the last beyond it). At a limit, above all of these: compound 3.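

In this assay, phenoxy on this aromatic carbon gives an at least 5.5-fold lower number from compound 3 to compound 4 (0.74 log units; beyond the scatter), so a group of 7 heavy atoms with one six-membered aromatic ring of carbon only, and with 0 hydrogen-bond donors, does not carry the read-out to the level of compound 3. Enlarging the ether itself, with phenyl in place of methyl on the oxygen, gives only a modest change, a 2.3-fold higher number from compound 2 to compound 4 (0.35 log units; beyond the scatter), while the comparison with hydroxymethyl gives a 1.8-fold higher number from compound 1 to compound 4 (0.26 log units; within the scatter). Compound 3 remains a limit, not a number: the limit of > 10000 nM in this assay, at which 1 of the 4 values shown sits.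

The compounds shown leave open how an amine, a carboxylic acid or a longer alkoxy chain on this aromatic carbon would read. They also leave open whether substituents on the outer phenyl ring of compound 4 would move its number.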